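Replacing a ring amine with an open-chain amine

A few compounds are considered here, and "the series" means these few. Any claim that something is new, unique, unknown or untested is made for them only; others in the source may bear on it.

All compounds here share one core and are compared in an assay on HEK293 cells for inhibition of sodium- and chloride-dependent glycine transporter 1 (Homo sapiens); on this read-out lower numbers stand for stronger inhibition and higher numbers for weaker inhibition. Compound 1 `O=S(=O)(NC[C@H](O)CN1CCCC1C1CCCCC1)c1cccc2ccccc12` gives 6310 nM; 6310 nM (2 entries). Compound 3 `CC(C)C1CCCN1C[C@@H](O)CNS(=O)(=O)c1cccc2ccccc12` gives 200 nM; 1000 nM (2 entries); its repeated entries the several entries of compound 3 in this assay, 200 nM; 1000 nM (2 entries) show how far the same compound can scatter. For the measured compounds named here, compound 2 `CCC1CCC(C)N(C[C@@H](O)CNS(=O)(=O)c2cccc3ccccc23)C1` gives 1000 nM, which is the only number it has on this read-out, two further entries having yielded no single number.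

Compound 4 `CCCN(C[C@@H](O)CNS(=O)(=O)c1cccc2ccccc12)C(C)(C)C` differs from compound 2 in one place: propyl(tert-butyl)amino in place of 5-ethyl-2-methylpiperidin-1-yl on a saturated chain carbon, two bonds along the chain from an oxygen on a saturated carbon. Going by the values given here, no two of the measured compounds differ in just one place, so no measured step tells directly what such a change does.

A moderate move toward weaker inhibition is expected, by the step of a 2.5-fold higher number from compound 2 to compound 4 (0.40 log units; beyond the scatter), somewhat beyond the usual scatter but not large. Among the compounds with values here, compound 4 is estimated at 2500 nM, in a range from 500 nM to 12000 nM, the wide band reflecting that no measured step supports the change.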

Compound 4, half-maximal inhibitory concentration: 1000 nM
For compound 4 the middle estimate is 2.5-fold (0.40 log units) above the measured one; the range from low to high includes it.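

In this assay the read-out shows no change at the digits printed from compound 2 to compound 4 (within the scatter). For the compounds shown here, this is the first direct comparison at this position, and it shows that, for this pair, the 5-ethyl-2-methylpiperidin-1-yl ring can be opened to propyl(tert-butyl)amino without a change that stands out from the scatter, so this ring is not needed to hold the value of compound 2. The comparison rests on a single number for each compound, and one compound can spread widely on repeat: the several entries of compound 3 in this assay, 200 nM; 1000 nM (2 entries)

Still open, on these data alone, is whether other open-chain amines, such as diethylamino, or a ring with a second hetero atom, such as morpholin-4-yl, would hold the same level at this position. As far as these compounds go, it is also open whether the same exchange would behave alike on the pyrrolidine-type amines of compound 1 and compound 3, whose amine groups carry other substituents.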